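Compound 4 against short-lived compound 3 in microsomes

This account rests on a few compounds, and the source may have more. Where it says the series, first, only, none or still open, it means among the compounds named here.

Three compounds with a shared core have been run in an ADME assay (liver) for metabolic stability, with Liver microsome (Homo sapiens) as the target, read by LC-MS, using microsomes and NADPH, tested at 1 uM; a lower number here means that the compound disappears faster, a higher number that the compound lasts longer. Compound 1 `CC(C)(C)c1cc(NC(=O)[C@@H]2CCCCN2CC2CCOCC2)no1` gives 0.183 h. Compound 2 `CC(C)(C)c1cc(NC(=O)[C@@H]2CCCCN2C(=O)C2CCS(=O)(=O)CC2)no1` reaches the upper limit of the assay, > 2 h, which is a limit and not a number. Compound 3 `CC(C)(C)c1cc(NC(=O)[C@@H]2CCCCN2C(=O)N2CCSCC2)no1` sits at the lower limit, < 0.0834 h, again a limit rather than a number. Compound 3 therefore stands at the short end of the three: the step of an at least 2.1-fold lower number from compound 1 to compound 3 (0.34 log units; beyond the scatter) and the step of an at least 23-fold lower number from compound 2 to compound 3 (1.37 log units; beyond the scatter) both run downward into it, and the second of them is large.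

Compound 4 `CC(C)(C)c1cc(NC(=O)[C@@H]2CCCCN2C(=O)N2CC[S+]([O-])CC2)no1` differs from compound 3 in one place: a group of 7 heavy atoms (4 carbon, 1 nitrogen, 1 oxygen, 1 sulfur; one six-membered non-aromatic ring with 2 hetero atoms) in place of a group of 6 heavy atoms (4 carbon, 1 nitrogen, 1 sulfur; one six-membered non-aromatic ring with 2 hetero atoms), on a carbonyl carbon. Among the compounds with values here, the only measured step that alters the group on that carbonyl carbon is the one from compound 2 to compound 3, where the number fell by at least a large margin, so an upward move is expected for compound 4, estimated as an at least 4.7-fold higher number from compound 3 to compound 4 (0.68 log units; beyond the scatter). The entering group counts one oxygen more than the leaving one, and the step from compound 2 to compound 3 is bounded by two limits, so the size of the rise is uncertain. Compound 4 is estimated at 0.4 h, in the range 0.08 h to 2 h.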

Compound 4, half-life in the Liver microsome assay: > 2 h
Compound 4 ended at the assay's limit (the forecaster's own chance of this, stated with the estimate: 25%); at least 5.0-fold (0.69 log units) between middle value and limit.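

Within the data shown here, on this carbonyl carbon, whose other neighbour is an amide-type nitrogen in a ring, the earlier compounds showed only an exchange of thiomorpholin-4-yl for the quite different 1,1-dioxothian-4-yl, whereas here a much smaller change to the ring spans a large move in the Liver microsome assay (an at least 23-fold higher number from compound 3 to compound 4 (1.37 log units; beyond the scatter)). In the Liver microsome assay compound 3 gives < 0.0834 h, which is a limit of the assay. In the Liver microsome assay compound 4 gives > 2 h, which is also a limit of the assay. The same compound also stands clear of the one carrying (oxan-4-yl)methyl on the amine nitrogen in a ring, again in the Liver microsome assay (an at least 10-fold higher number from compound 1 to compound 4 (1.03 log units; beyond the scatter)). In a physicochemical assay for solubility, read by HPLC, at pH 6.8 (a lower number here means a less soluble compound, a higher number a more soluble compound), compound 3 gives 46 ug/mL and compound 4 gives 68 ug/mL. In the physicochemical assay the replacement of thiomorpholin-4-yl gives only a small step within the scatter (a 1.5-fold higher number from compound 3 to compound 4 (0.17 log units; within the scatter)), so the two read-outs do not move together for this pair.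

On these data alone, the step between compound 2 and compound 4 cannot be read, and how long either compound lasts remains open, because both stand at one limit of the assay: the limit of > 2 h in the Liver microsome assay, at which 2 of the 4 values shown sit. The compounds shown also leave open what morpholin-4-yl, which has an oxygen and no sulfur in its ring, would give on this carbonyl carbon.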